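Thiophen-3-yl in place of phenyl: working notes

The compounds below may be only part of what the source reports. "The series", "measured", "known", "first", "only" and "open" are said of these compounds alone.

Compound 1 `C=C/C=C\[C@H](C)[C@H](OC(N)=O)[C@@H](C)[C@H](O)[C@@H](C)C/C(C)=C\[C@H](C)[C@@H](O)[C@@H](C)/C=C\CCc1cccc(O)c1C`: 270 nM
Compound 2 `C=C/C=C\[C@H](C)[C@H](OC(N)=O)[C@@H](C)[C@H](O)[C@@H](C)C/C(C)=C\[C@H](C)[C@@H](O)[C@@H](C)/C=C\CCc1cccc(Cl)c1`: 380 nM
Compound 3 `C=C/C=C\[C@H](C)[C@H](OC(N)=O)[C@@H](C)[C@H](O)[C@@H](C)C/C(C)=C\[C@H](C)[C@@H](O)[C@@H](C)/C=C\CCc1ccccc1`: 350 nM

All three values come from a functional assay on SK-OV-3 cells (Homo sapiens) for cytotoxicity; a lower number here means a stronger inhibitor, a higher number a weaker inhibitor. There, compound 3 gives 350 nM, which lies within the scatter of both other compounds, so it has no separate standing among them. Its two steps show this: a 1.3-fold higher number from compound 1 to compound 3 (0.11 log units; within the scatter) and a 1.1-fold lower number from compound 2 to compound 3 (0.04 log units; within the scatter).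

The next compound is compound 4 `C=C/C=C\[C@H](C)[C@H](OC(N)=O)[C@@H](C)[C@H](O)[C@@H](C)C/C(C)=C\[C@H](C)[C@@H](O)[C@@H](C)/C=C\CCc1ccsc1`, which carries one change from compound 3: thiophen-3-yl in place of phenyl on a saturated chain carbon, two bonds along the chain from a double-bonded chain carbon. Put simply, this is thiophen-3-yl in place of phenyl on a saturated chain carbon, two bonds along the chain from a double-bonded chain carbon.

Going by the values given here, no measured compound carries a five-membered aromatic ring, so no step tests this exchange directly. The closest evidence is the set of changes to the aromatic group at this same place. Besides the two steps above, there is a 1.4-fold higher number from compound 1 to compound 2 (0.15 log units; within the scatter). None of the three leaves the scatter in this assay, although the groups involved differ in their substituents. Three compounds make a narrow basis, but they give no reason to expect a direction.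

The expected step is no change at the digits printed from compound 3 to compound 4 (within the scatter), with none anticipated beyond the scatter. Compound 4 is estimated at 350 nM, with an expected range of 180 nM to 700 nM.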

Compound 4, half-maximal inhibitory concentration: 440 nM
Estimate against measurement, compound 4: 1.3-fold (0.10 log units) below; measured number inside the range.
By their numbers in this assay, from the lowest: compounds 1, 3, 2 and 4 (each within the scatter of the next).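

In this assay, the exchange of phenyl for thiophen-3-yl now has a direct reading, a 1.3-fold higher number from compound 3 to compound 4 (0.10 log units; within the scatter), so this five-membered aromatic ring with one sulfur atom fits the pattern of the earlier changes on a saturated chain carbon, two bonds along the chain from a double-bonded chain carbon. The comparisons with the two substituted phenyl groups agree, with a 1.2-fold higher number from compound 2 to compound 4 (0.06 log units; within the scatter) and a 1.6-fold higher number from compound 1 to compound 4 (0.21 log units; within the scatter), so every step among the four compounds stays within the scatter, even though ring size, hetero atom and substituents all vary at this place. Nothing available explains why these numbers stay together.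

From the compounds shown here alone, how a cyclohexyl ring, an amine or a carboxylic acid would read at this place remains open, as does the effect of a longer chain leading to the aromatic ring. Also open is whether the same flat picture would appear in other cell lines, as the compounds shown are compared only in this assay.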